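Swapping a saturated ring for a bromophenyl on the chain

The source may report more compounds than this note shows. Statements on the series, on what has been measured and on what is new or still open speak of the compounds shown alone.

Measured compounds:
- compound 1, `FC(F)(F)c1cc(NC[C@H]2CCCN2)c2cn[nH]c2c1`: 55%
- compound 2, `O=[N+]([O-])c1cc(Cl)ccc1CNc1cc(C(F)(F)F)cc2[nH]ncc12`: 90%
- compound 3, `O=[N+]([O-])c1ccc(CNc2cc(Br)cc3[nH]ncc23)cc1`: 87%

In an assay for inhibition of Tryptophan 2,3-dioxygenase (Homo sapiens), with stated times of 10 min and 60 min, tested at 10 uM (a higher number here means a stronger effect of the compound at the concentration tested, a lower number a weaker effect), compound 1 gives 55%, the lowest of the three numbers. Compound 3 stands above it by a margin beyond the usual scatter, and compound 2 stands higher still, also beyond the scatter. Going by the values given here, neither compound 2 nor compound 3 differs from compound 1 in a single place, so no step between measured compounds is recorded here; only their values can be compared.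

The unmeasured compound 4, `FC(F)(F)c1cc(NCc2cccc(Br)c2)c2cn[nH]c2c1`, differs from compound 1 in one place: 3-bromophenyl in place of pyrrolidin-2-yl on a saturated chain carbon bound to a nitrogen on an aromatic ring. The saturated ring that leaves carries the only donor and acceptor of the group, while the 3-bromophenyl that enters brings an aromatic ring of carbon alone.

Among the compounds with values here, with no measured single-place step to lean on, the expected step from compound 1 to compound 4 is estimated at a number 23 percentage points higher from compound 1 to compound 4 (beyond the scatter) in this assay, upward and beyond the scatter, because compound 2 gives 90% and compound 3 gives 87%, both of them carrying an aromatic ring rather than a saturated one. For compound 4 the expected inhibition is therefore 78%, with a range from 58% to 92%.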

Compound 4, a percentage reported as inhibition, at one concentration (the size of the read-out at that concentration, not a potency): 67%
Compound 4: middle estimate off by 11 percentage points, on the high side; the measured number falls inside the stated range.
By their numbers in this assay, from the lowest: compound 1; then compound 4; then compounds 3 and 2 (each within the scatter of the next).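

In this assay, putting 3-bromophenyl in place of pyrrolidin-2-yl on a saturated chain carbon bound to a nitrogen on an aromatic ring gives a modest rise (a number 12 percentage points higher from compound 1 to compound 4 (beyond the scatter)). Going by these compounds alone, this is the first single-place comparison at this position, and it shows that the pyrrolidin-2-yl, with its hydrogen-bond donor, acceptor and defined stereocentre, can leave without any loss of inhibition at the concentration tested. No measurement shown here explains the rise.

The compounds shown cannot separate a contribution of the aromatic ring from one of the bromine, and an unsubstituted phenyl at this place would help to tell the two apart. It also remains open how a primary amine on an open chain would compare with the pyrrolidin-2-yl, and a single-concentration read-out gives no potency for any of these compounds.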